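Aryl urea series: ethyl for methyl on the aniline ring

This account rests on a few compounds, and the source may have more. Where it says the series, first, only, none or still open, it means among the compounds named here.

Compound 1 `Cc1ccccc1NC(=O)N[C@@H](C)c1ccccc1` and compound 3 `CCc1ccccc1NC(=O)N[C@@H](C)c1ccccc1` share a core; in an ADME assay on the whole organism with Oryza sativa as the target, tested at 0.1 uM (a higher number here means a weaker effect of the compound at the concentration tested, a lower number a stronger effect), compound 1 gives 100% and compound 3 gives 100%. The step of no change at the digits printed from compound 1 to compound 3 (within the scatter) is the change (methyl in place of hydrogen on a saturated chain carbon bound to an aromatic carbon). Compound 2 `Cc1cccc(NC(=O)N[C@H](C)c2ccccc2)c1` carries the same atoms joined differently; the difference between the two cores is not broken down here. In this assay compound 2 gives 100%, which lies level with compounds 1 and 3 at the digits shown. Compound 4 `CCc1cccc(NC(=O)N[C@H](C)c2ccccc2)c1` is not yet measured. It differs from compound 2 by methyl in place of hydrogen on a saturated chain carbon bound to an aromatic carbon, the same change as that from compound 1 to compound 3. The step is expected to be no change at the digits printed from compound 2 to compound 4 (within the scatter), because no change at the digits printed from compound 1 to compound 3 (within the scatter) showed nothing beyond the scatter. Compound 4 is therefore estimated at 100% in this assay, between 90% and 100%.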

Compound 4, a percentage reported as activity, at one concentration (the size of the read-out at that concentration, not a potency): 97%
Beside the measured number, compound 4's estimate is 3 percentage points above it; the measured number falls inside the stated range.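

Methyl to ethyl in this assay gives a number 3 percentage points lower from compound 2 to compound 4 (within the scatter) on the core of compound 2, and set beside the step on the core of compound 1, it shows no difference between the two cores: the same change on two cores in this assay, no change at the digits printed (within the scatter) from compound 1 to compound 3 and a number 3 percentage points lower (within the scatter) from compound 2 to compound 4, 3 percentage points apart, within the scatter of two such steps

So within this pair of cores, the change carries across with both steps inside the scatter. Within the data shown here, this does not show that the change is without effect on other cores or at other concentrations, since the read-out comes from a single concentration and only two cores are compared.

Open, on these data alone, is whether a longer chain such as propyl, or an amine or a carboxylic acid in the same place, would give a step beyond the scatter. Also open, as far as these compounds go, is whether the two cores would still match for such groups.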